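Aryl exchange on the shared core: compound 2 to compound 3

The compounds below may be only part of what the source reports. "The series", "measured", "known", "first", "only" and "open" are said of these compounds alone.

Compound 1 `COc1ccc(C(c2ccccn2)c2nc(-c3ccc(Cl)cc3)c(CC(=O)O)s2)cc1` and compound 2 `O=C(O)Cc1sc(C(c2ccc(F)cc2)c2ccc(F)cc2)nc1-c1ccccc1` share the core that carries the carboxymethyl group. In an in vitro assay on HEK385-7 cells for displacement of a labelled ligand from prostaglandin D2 receptor 2 (Homo sapiens) (on this read-out higher numbers stand for weaker inhibition and lower numbers for stronger inhibition), compound 1 gives 61 nM. In this assay compound 2 gives 16 nM, the lowest of the two numbers shown; its gap to compound 1 lies beyond the scatter. Compound 3 `Cc1cc(-c2nc(C(c3ccc(F)cc3)c3ccc(F)cc3)sc2CC(=O)O)cnc1N` is not yet measured. Against compound 2 it shows one change: 6-amino-5-methylpyridin-3-yl in place of phenyl on an aromatic carbon. Going by the values given here, no measured pair isolates such an exchange on this core, since compound 1 and compound 2 differ at several places at once, so the size of the step cannot be read from the data. The step from compound 2 to compound 3 is therefore expected to be small, with no clear direction, and the expected step of no change at the digits printed from compound 2 to compound 3 (within the scatter) stays within the scatter. Compound 3 is expected to give 16 nM, with a range from 5 nM to 50 nM.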

Compound 3, half-maximal inhibitory concentration: 880 nM
For compound 3 the middle estimate is 55-fold (1.74 log units) below the measured one; measured number above the stated range.
By their numbers in this assay, from the lowest: compound 2; then compound 1; then compound 3.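

The aromatic carbon next to the ring nitrogen and next to the ring atom that bears a carboxymethyl group is sensitive to what it carries: in this assay, 6-amino-5-methylpyridin-3-yl in place of phenyl gives a 55-fold higher number from compound 2 to compound 3 (1.74 log units; beyond the scatter), a large step. Going by these compounds alone, this is the first pair that isolates a single exchange, and it shows that this position does not accept every six-membered aromatic ring equally on the shared core. No available measurement gives a reason for the loss.

Going by these compounds, the ring nitrogen, the amine and the methyl enter together, so it remains open which of them goes with the step. A plain pyridin-3-yl, or a phenyl carrying only an amine or only a methyl, would separate these contributions.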